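From methyl to 3-carboxyphenyl on an aromatic nitrogen

This account rests on a few compounds, and the source may have more. Where it says the series, first, only, none or still open, it means among the compounds named here.

In an in vivo ADME assay on the whole organism for pharmacokinetics, with Rattus norvegicus as the target (a lower number here means slower removal, a higher number faster removal of the compound), compound 1 (`CCCSc1ncccc1C(=O)NC1CCCCC1`) gives 41 mL/min/kg and compound 2 (`CCCSc1c(C(=O)NC2CCCCC2)cnn1C`) gives 21 mL/min/kg, so these two numbers lie within the usual scatter of each other. Compound 3 (`CCCSc1c(C(=O)NC2CCCCC2)cnn1-c1cccc(C(=O)O)c1`) has 3-carboxyphenyl in place of methyl on an aromatic nitrogen. Among the compounds with values here, no measured pair shows a change of this kind, which leaves the expectation resting on the structural change alone. The expected step is a 2.6-fold lower number from compound 2 to compound 3 (0.42 log units; beyond the scatter), downward and beyond the scatter. For compound 3 the estimate is 8 mL/min/kg, with an expected range of 2 mL/min/kg to 30 mL/min/kg.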

Compound 3, clearance in the Rattus norvegicus assay: 17 mL/min/kg
The estimate for compound 3 lay 2.1-fold (0.33 log units) below the measured number, and the stated range covers the measured number.
By their numbers in the Rattus norvegicus assay, from the lowest: compounds 3, 2 and 1 (each within the scatter of the next, the first and the last beyond it).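

Putting 3-carboxyphenyl in place of methyl on this aromatic nitrogen adds a ring and far more heavy atoms, yet in the Rattus norvegicus assay the step stays small: a 1.2-fold lower number from compound 2 to compound 3 (0.09 log units; within the scatter). This position therefore holds a much larger group without the clearance number leaving the scatter. In a physicochemical assay for lipophilicity, using the shake flask method, at pH 7.4 (on this read-out higher numbers stand for higher lipophilicity and lower numbers for lower lipophilicity), compound 2 gives 3 and compound 3 gives 0.7 as distribution coefficient. In the physicochemical assay the same change has a large effect, yet clearance does not follow it: the measured distribution coefficient of compound 2, 3, and of compound 3, 0.7, a number 2.30 log units lower (beyond the scatter)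

The compounds shown do not separate the contribution of the phenyl ring from that of its carboxylic acid. A plain phenyl group or an aminophenyl group on the same nitrogen would help to tell them apart.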